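Aryl variation on the shared core: notes toward compound 4

The source may hold more compounds than are shown below. What is called first, only, known or untested is meant among the compounds shown, and "the series" means these compounds.

Measured so far:
compound 1 `Nc1scc(CN2CCN(c3ccc(F)cc3Cl)CC2)c1C(=O)c1ccc(Cl)cc1` gives 6.1% in a functional assay on CHO cells with adenosine receptor A1 (Homo sapiens) as the target, read by cAMP accumulation and immunoassay, with a stated time of 6 min, tested at 0.01 uM; a higher number here means a weaker effect of the compound at the concentration tested, a lower number a stronger effect
compound 2 `Nc1scc(CN2CCN(c3ccc([N+](=O)[O-])cc3)CC2)c1C(=O)c1ccc(Cl)cc1` gives -12% in this assay
compound 3 `Nc1scc(CN2CCN(c3cccc(C(F)(F)F)c3)CC2)c1C(=O)c1ccc(Cl)cc1` gives -8.2% in this assay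

Compound 3 stands second highest of the three numbers. Its nearest neighbour is compound 2, with a number 3.8 percentage points higher from compound 2 to compound 3 (within the scatter), a gap within the scatter; its furthest is compound 1, with a number 14.3 percentage points lower from compound 1 to compound 3 (beyond the scatter), beyond the scatter.

Compound 4 `Nc1scc(CN2CCN(c3ccccc3C(F)(F)F)CC2)c1C(=O)c1ccc(Cl)cc1` differs from compound 3 by 2-(trifluoromethyl)phenyl in place of 3-(trifluoromethyl)phenyl on an amine nitrogen in a ring. Within the data shown here, no measured step moves a group within the aryl ring, so the bearing of the data is indirect. The two steps that exchange the whole aryl group from compound 1, a number 18.1 percentage points lower from compound 1 to compound 2 (beyond the scatter) and a number 14.3 percentage points lower from compound 1 to compound 3 (beyond the scatter), were modest and downward, while the exchange between the other two aryl groups, a number 3.8 percentage points higher from compound 2 to compound 3 (within the scatter), stayed within the scatter. Compound 1 carries the only 2-substituted aryl among the measured compounds and sits highest, which allows for a small rise, but nothing measured demands it.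

The expected step for compound 4 is therefore a number 5.2 percentage points higher from compound 3 to compound 4 (within the scatter), within the scatter. In this assay compound 4 is estimated at -3%, with a range of -19% to 13%.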

Compound 4, a percentage reported as activity, at one concentration (the size of the read-out at that concentration, not a potency): 0%
The estimate for compound 4 lay 3 percentage points below the measured number; the measured number falls inside the stated range.
By their numbers in this assay, from the lowest: compounds 2, 3, 4 and 1 (each within the scatter of the next, the first and the last beyond it).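

Shifting the trifluoromethyl group, the first such shift on this aryl group, gives a number 8.2 percentage points higher from compound 3 to compound 4 (within the scatter) in this assay, so 2-(trifluoromethyl)phenyl and 3-(trifluoromethyl)phenyl cannot be told apart on the amine nitrogen in the ring. Compound 4 nevertheless separates from the 4-nitrophenyl analogue, with a number 12 percentage points higher from compound 2 to compound 4 (beyond the scatter), while it stays unresolved from the 2-chloro-4-fluorophenyl analogue, with a number 6.1 percentage points lower from compound 1 to compound 4 (within the scatter), although compound 3 also stays unresolved from compound 4 and so keeps this from being a clear effect of the 2-substituted aryl groups. No evidence bears on the origin of these steps.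

Open, going by these compounds, is whether a phenyl ring carrying a carboxylic acid, an amine or a methoxy group would fall within the same narrow band. Also open, on these data alone, is whether these small differences at one concentration persist at other concentrations.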